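The compounds below may be only part of what the source reports. "The series", "measured", "known", "first", "only" and "open" are said of these compounds alone.

Working notes on the series. Of the compounds shown here, two of the shared core have so far been measured in a functional assay on cells (Pituitary gland cell) for antagonist activity at Gonadotropin-releasing hormone receptor (Rattus norvegicus); on this read-out lower numbers stand for stronger inhibition and higher numbers for weaker inhibition. Compound 1 `O=[N+]([O-])c1cc2c(OCCC3CCCCN3)c(-c3cccs3)c(O)nc2cc1Cl` gives 220 nM. Within the data shown here, compound 2 `O=[N+]([O-])c1cc2c(OCCC3CCCCN3)c(-c3ccc4ccccc4c3)c(O)nc2cc1Cl` gives 53 nM, the lower of the two numbers; the only measured step, a 4.2-fold lower number from compound 1 to compound 2 (0.62 log units; beyond the scatter), is the gap between them, and it rests on a single exchange of the aromatic substituent. Compound 3 `O=[N+]([O-])c1cc2c(OCCC3CCCCN3)c(-c3ccccc3)c(O)nc2cc1Cl` is not yet measured. It differs from compound 2 by phenyl in place of naphthalen-2-yl on an aromatic carbon. The measured step bears on this change only in part: it shows that the group with two six-membered aromatic rings gave the lower number than thiophen-2-yl, while phenyl itself has no measurement. Going from two rings to one is expected to move this assay back upward, by a 2.6-fold higher number from compound 2 to compound 3 (0.42 log units; beyond the scatter), a step smaller than the measured one. Compound 3 is accordingly estimated at 140 nM, within a range from 50 nM to 450 nM.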

Compound 3, half-maximal inhibitory concentration: 410 nM
Compound 3: the middle estimate sits 2.9-fold (0.47 log units) below what was measured; low and high end bracket the measured number.
By their numbers in this assay, from the lowest: compound 2; then compounds 1 and 3 (each within the scatter of the next).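

In this assay, the step from naphthalen-2-yl to phenyl on this aromatic carbon, ortho to the hydroxy group, is a 7.7-fold higher number from compound 2 to compound 3 (0.89 log units; beyond the scatter), so the second six-membered aromatic ring now has a measured step of its own. The two groups with a single aromatic ring are not separated, at a 1.9-fold higher number from compound 1 to compound 3 (0.27 log units; within the scatter), which places the difference among these three compounds with naphthalen-2-yl alone and shows no separation between phenyl and thiophen-2-yl. Nothing at hand explains why the second ring matters here.

The compounds shown leave open whether the lower number belongs to naphthalen-2-yl specifically or would also appear with naphthalen-1-yl or biphenyl-4-yl at this carbon. They also leave open how a phenyl ring carrying a methoxy group or an amine would compare with phenyl itself.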